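From isopropoxy to butoxy: notes on compound 4

The source may hold more compounds than are shown below. What is called first, only, known or untested is meant among the compounds shown, and "the series" means these compounds.

Values in an ADME assay on BEAS-2B cells (Homo sapiens) for cytotoxicity, read by MTT assay, with a stated time of 72 h (a higher number here means a weaker inhibitor, a lower number a stronger inhibitor), are as follows
compound 1 `CC(C)OC1OC(=O)C(Cl)=C1N1CCCCC1` gives > 400000 nM
compound 2 `CC(C)(C)COC1OC(=O)C(Cl)=C1Cl` gives 59000 nM
compound 3 `CC(C)(C)OC1OC(=O)C(Cl)=C1Cl` gives 23100 nM

Compound 1 gives > 400000 nM, and this is a limit of the measurement, not a number. Compound 2 and compound 3 give numerical values, but neither differs from compound 1 in one place only, so no measured step sizes the change under study.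

Compound 4 `CCCCOC1OC(=O)C(Cl)=C1N1CCCCC1` keeps the core of compound 1 and changes one group: butyl in place of isopropyl on an oxygen on a saturated carbon. In this assay a small step towards stronger inhibition is expected, possibly none beyond the scatter, and a further reading at the limit would not be surprising. The expected step is an at least 1.6-fold lower number from compound 1 to compound 4 (0.20 log units; that floor lies within the scatter). Compound 4 is estimated at 250000 nM, with an expected range of 80000 nM to 600000 nM.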

Compound 4, half-maximal inhibitory concentration: 172000 nM
The estimate for compound 4 lay 1.5-fold (0.16 log units) above the measured number, within the range that was stated.
By their numbers in this assay, from the lowest: compound 3; then compound 2; then compound 4. At a limit, above all of these: compound 1.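

In this assay compound 1 gives > 400000 nM, which is a limit of the assay and not a number. On the shared core, compound 4 gives 172000 nM, so isopropoxy to butoxy brings this core onto a numerical reading and shows that the group on this oxygen can shift the read-out, with an at least 2.3-fold lower number from compound 1 to compound 4 (0.36 log units; beyond the scatter). This step is a floor rather than a full size, and its true extent remains unknown: the limit of > 400000 nM in this assay, at which 1 of the 4 values shown sits.

A single pair cannot separate the effect of chain length from that of branching, so no trend along the alkyl chain can be claimed. Where a straight propyl group, a longer chain such as hexyl, or an amine at the end of the butyl chain would fall in this assay remains open.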